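The compounds below may be only part of what the source reports. "The series", "measured", "known", "first", "only" and "open" are said of these compounds alone.

Compound 3, `COc1ccccc1N1CCN(CCCCNC(=O)c2ccc([N+](=O)[O-])cc2)CC1`, sits at the lowest of the two numbers shown: in an assay on frontal cortex for binding affinity to Adrenergic receptor alpha-1 (Rattus norvegicus), read by radioligand binding (on this read-out lower numbers stand for stronger inhibition and higher numbers for weaker inhibition), compound 3 gives 14 nM. Compound 1, `O=C1c2ccccc2C(=O)N1CCCCN1CCN(c2ccc([N+](=O)[O-])cc2)CC1`, gives 378 nM in this assay. For compound 2, `CC(=O)Nc1ccc(N2CCN(CCCCN3C(=O)c4ccccc4C3=O)CC2)cc1`, this assay reports only a limit, < 1000 nM, which is the point recorded in the limit of < 1000 nM in this assay, at which 1 of the 3 values shown sits. Compound 4, `COc1ccccc1N1CCN(CCCCNC(=O)c2ccc(N)cc2)CC1`, differs from compound 3 by one change: amino in place of nitro on an aromatic carbon. Among the compounds with values here, the only measured step that also removes a nitro group, a step that the limit leaves unreadable from compound 1 to compound 2, cannot be sized because of the limit (the limit of < 1000 nM in this assay, at which 1 of the 3 values shown sits), so neither direction nor size can be read from it. The step of a 2.1-fold higher number from compound 3 to compound 4 (0.33 log units; beyond the scatter) is therefore expected to be modest, with wide uncertainty. Compound 4 is estimated at 30 nM, with a range from 8 nM to 120 nM.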

Compound 4, inhibition constant: 23 nM
Compound 4: middle estimate off by 1.3-fold (0.12 log units), on the high side, within the range that was stated.
By their numbers in this assay, from the lowest: compounds 3 and 4 (each within the scatter of the next); then compound 1.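

In this assay, amino in place of nitro, on a six-membered aromatic ring and para to a large group, gives a 1.6-fold higher number from compound 3 to compound 4 (0.22 log units; within the scatter), so this swap leaves the number within the usual scatter. Within the data shown here, this is the first step away from a nitro group whose size can be read. The earlier step, to acetamido, cannot be read, as compound 2 carries a limit: the limit of < 1000 nM in this assay, at which 1 of the 4 values shown sits.

Still open, on these data alone, is how an acetamido group, a methoxy group or a chlorine atom would read at this position on the core of compound 3. Also open, as far as these compounds go, is whether a longer chain would change the number.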